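Swapping a Maleimide Ring for an Ethynyl Group

The compounds below may be only part of what the source reports. "The series", "measured", "known", "first", "only" and "open" are said of these compounds alone.

Compound 2 `O=C1C=CC(=O)N1c1cc(C(F)(F)F)cc(C(F)(F)F)c1` carries a five-membered non-aromatic ring on the shared core that bears two trifluoromethyl groups. In an ADME assay for pharmacokinetics, read by LC-MS, in phosphate buffer, with a stated time of 72 h, at pH 7.4, tested at 250 uM (on this read-out higher numbers stand for a longer-lived compound and lower numbers for a shorter-lived compound), compound 2 gives < 0.017 h, which is a limit of the assay rather than a measured number. Compound 1 `C=CS(=O)(=O)c1cc(C(F)(F)F)cc(C(F)(F)F)c1` differs from it only in the group on that aromatic carbon. In this assay compound 1 gives < 0.017 h, again a limit. The step that the two limits leave unreadable from compound 1 to compound 2 is therefore not readable, and the whole of the evidence is the limit of < 0.017 h in this assay, at which 2 of the 2 values shown sit. Compound 3 `C#Cc1cc(C(F)(F)F)cc(C(F)(F)F)c1` has not yet been measured; the change a group of 2 heavy atoms (2 carbon; no ring) in place of a group of 7 heavy atoms (4 carbon, 1 nitrogen, 2 oxygen; one five-membered non-aromatic ring with 1 hetero atom), on an aromatic carbon removes the ring altogether. Among the compounds with values here, no measured step tells how an ethynyl group fares here, so the expectation rests on very little. Compound 3 is expected to reach 100 h, with a range from 5 h to 2000 h. That would amount to an expected step of an at least 5800-fold higher number from compound 2 to compound 3 (3.76 log units; beyond the scatter).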

Compound 3, half-life: > 50 h
Compound 3: no number, only a limit (the forecaster's own chance of this, stated with the estimate: 55%); the middle value is on the limit's open side.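

In this assay, a short half-life is not fixed by the shared core, since the group on this aromatic carbon alone separates the compounds: an at least 2900-fold higher number from compound 2 to compound 3 (3.46 log units; beyond the scatter), and an at least 2900-fold higher number from compound 1 to compound 3 (3.46 log units; beyond the scatter). Within the data shown here, compound 1 and compound 2 both sat at the same limit, so they could not show whether any change at this place would matter, and the ethynyl group is the first one here to give a different result. Compound 3 gives > 50 h, which is a limit and not a number: the limit of > 50 h in this assay, at which 1 of the 3 values shown sits.

The compounds shown leave open how long compound 3 actually lasts. They also leave open whether the triple bond itself matters, which an ethyl group at the same place would test, and how a nitrile or an amine would fare in this assay.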